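Isobutyl ester variant of the thiazolyl dihydropyridine series

This account rests on a few compounds, and the source may have more. Where it says the series, first, only, none or still open, it means among the compounds named here.

Compound 1 `COC(=O)C1=C(C)NC(C)=C(C(=O)OC)C1c1csc(-c2ccc(Cl)cc2)n1` stands at the lower end of the two numbers seen in an assay on isolated protein for antagonist activity at Voltage-dependent L-type calcium channel subunit alpha-1C (Cavia porcellus), with a stated time of 15 min (a lower number here means a stronger inhibitor, a higher number a weaker inhibitor), where compound 1 gives 4430 nM. Compound 2 `CC1=C(C(=O)OCCc2ccccc2)C(c2csc(-c3ccc(Cl)cc3)n2)C(C(=O)OCCc2ccccc2)=C(C)N1` gives 500000 nM in this assay, far weaker. Compound 3 `COC(=O)C1=C(C)NC(C)=C(C(=O)OCC(C)C)C1c1csc(-c2ccc(Cl)cc2)n1` differs from compound 1 by one change: isopropyl in place of hydrogen on a saturated chain carbon bound to an oxygen next to a carbonyl group. With no single-site comparison measured, the step from compound 1 to compound 3 is expected to be modest, towards a lower number, as a 3.0-fold lower number from compound 1 to compound 3 (0.47 log units; beyond the scatter). Compound 3 is therefore estimated at 1500 nM in this assay, within 300 nM to 8000 nM.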

Compound 3, half-maximal inhibitory concentration: 46900 nM
For compound 3 the middle estimate is 31-fold (1.50 log units) below the measured one, and the stated range ends below it.
By their numbers in this assay, from the lowest: compound 1; then compound 3; then compound 2.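

Going from methoxycarbonyl to isobutoxycarbonyl gives the first single-site reading in this assay: an 11-fold higher number from compound 1 to compound 3 (1.02 log units; beyond the scatter). On a saturated chain carbon bound to an oxygen next to a carbonyl group, isopropyl in place of hydrogen is therefore not a neutral change, and this one pair points to a clear loss of inhibition. Nothing available accounts for the size of this step. Going by these compounds, whether an ethyl or a straight butyl chain here gives a similar loss stays open, as does the effect of a carboxylic acid in place of this ester.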